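The source may hold more compounds than are shown below. What is called first, only, known or untested is meant among the compounds shown, and "the series" means these compounds.

Working notes on the thiosemicarbazone series.

Compound 1 `COc1cccc(NC(=S)N/N=C/c2ccc3ccccc3n2)c1` is the reference point for the step considered here. In a functional assay on HL-60 cells (Homo sapiens) for antiproliferative activity, read by sulforhodamine B assay, with a stated time of 72 h (a lower number here means a stronger inhibitor, a higher number a weaker inhibitor), compound 1 gives 71200 nM, the highest of the two numbers recorded in the set. Compound 2 `CN(C)C(=S)N/N=C/c1ccc2cccnc2n1` gives 560 nM in this assay, a far lower number, and the gap to compound 1 lies well beyond the usual scatter. Compound 3 `CN(C)C(=S)N/N=C/c1cc2cccnc2s1` returns only a limit in this assay, > 100000 nM, and not a number; this is the limit of > 100000 nM in this assay, at which 1 of the 3 values shown sits. Among the measured compounds shown here, no two of the measured compounds differ in a single place, so no measured step is available to calibrate the change below.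

Compound 4 `S=C(N/N=C/c1ccc2ccccc2n1)Nc1ccccc1` is not yet measured. It differs from compound 1 by hydrogen in place of methoxy on an aromatic carbon. The change is small in size and sits at the outer edge of the molecule, away from the shared core that compound 1 and compound 4 have in common. With no measured step of this kind in the set, the expectation is that the change from compound 1 to compound 4 falls within the scatter, or at most a modest shift in this assay, with no preferred direction: the expected step is a 1.1-fold lower number from compound 1 to compound 4 (0.04 log units; within the scatter). Compound 4 is therefore estimated at 65000 nM in this assay, with a plausible range from 25000 nM to 150000 nM. A limit rather than a number is also a real possibility for compound 4.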

Compound 4, half-maximal inhibitory concentration: 9130 nM
Beside the measured number, compound 4's estimate is 7.1-fold (0.85 log units) above it; measured number below the stated range.
By their numbers in this assay, from the lowest: compound 2; then compound 4; then compound 1. At a limit, above all of these: compound 3.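

The change from 3-methoxyphenyl to phenyl provides the series' only measured single-place step: in this assay, hydrogen in place of methoxy gives a 7.8-fold lower number from compound 1 to compound 4 (0.89 log units; beyond the scatter). This position, on an aromatic carbon of a six-membered aromatic ring of carbon only and meta to a large group, is therefore not silent in this assay, since losing 2 heavy atoms at the outer edge of the molecule moves the number beyond the scatter, and in this single pair the lower number goes with hydrogen. Nothing measured in the set bears on the cause of this step.

On these data alone, a single pair fixes only one direction at this place, so it remains open whether fluorine, hydroxy, ethoxy, an amine or a carboxylic acid there would give a number close to that of compound 4, close to that of compound 1, or outside both. Among the compounds shown here, also open is whether the same step would hold on any core other than the one shared by compound 1 and compound 4.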